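The source may report more compounds than this note shows. Statements on the series, on what has been measured and on what is new or still open speak of the compounds shown alone.

Compound 1 `O=C(O)CCc1ccncc1-c1ccc2ccccc2c1`: in a functional assay on KB cells (Homo sapiens) for inhibition, read by sulforhodamine B assay, with a stated time of 72 h (a lower number here means a stronger inhibitor of growth, a higher number a weaker inhibitor of growth), compound 1 gives > 10000 nM, which is a limit of the assay.
Compound 2 `NNC(=O)CCc1ccncc1-c1ccc2ccccc2c1`: in this assay compound 2 gives > 10000 nM, again a limit of the assay.
Compound 3 `O=C(/C=C/c1ccncc1-c1ccc2ccccc2c1)N1CCOCC1`: in this assay compound 3 gives > 10000 nM, once more a limit of the assay.

Compound 3 therefore stands at the edge of what this assay can report, and it shares that position with every other compound shown: all three values sit at the limit of > 10000 nM in this assay, at which 3 of the 3 values shown sit. Among the measured compounds shown here, no compound in this set has a number that would place it above or below another.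

Compound 4 `CCOC(=O)/C=C/c1ccncc1-c1ccc2ccccc2c1` differs from compound 3 in one place, (ethoxy in place of morpholin-4-yl on a carbonyl carbon). For the measured compounds named here, the only measured step, a step that the two limits leave unreadable from compound 1 to compound 2, runs between two limits and so gives no readable size; it also concerns a different carbonyl substituent. Going by the values given here, no measured step touches the morpholin-4-yl or the ethoxy group. The step from compound 3 to compound 4 thus cannot be sized from the measured compounds, and the account expects a step that the limit leaves unreadable from compound 3 to compound 4 to be no more than the scatter. Compound 4 is accordingly expected to give about 15000 nM, with a range from 5000 nM to 50000 nM, and most probably only a limit again.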

Compound 4, concentration for 50% growth inhibition: > 10000 nM
Compound 4 gave a limit, no number; the forecaster's own chance of this, stated with the estimate: 80%; the middle value is on the limit's open side.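

Compound 4 again gives only a limit, so its steps from compound 1, compound 2 and compound 3 cannot be read, and all four compounds rest at the same edge: the limit of > 10000 nM in this assay, at which 4 of the 4 values shown sit.

The compounds shown leave open how far any of them lies from another in this assay.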